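Isopropylurea in the dithiocarbamate series: expected effect

The compounds below may be only part of what the source reports. "The series", "measured", "known", "first", "only" and "open" are said of these compounds alone.

Measured so far:
- compound 1 `CC(C)NC(=O)N1CCN(C(=S)SCc2cn(Cc3ccccc3F)nn2)CC1`: 20800 nM
- compound 2 `NC(=O)N1CCN(C(=S)SCc2cn(Cc3ccc(Cl)cc3)nn2)CC1`: > 128000 nM

In a functional assay on EC9706 cells (Homo sapiens) for cytotoxicity, read by MTT assay, with a stated time of 72 h (on this read-out higher numbers stand for weaker inhibition and lower numbers for stronger inhibition), compound 1 gives 20800 nM. Compound 2 reaches only a limit of the assay in this assay, > 128000 nM, so no number stands for it and it sits at the limit of > 128000 nM in this assay, at which 1 of the 2 values shown sits. Going by the values given here, compound 1, which carries the isopropylcarbamoyl group, is thus the only member of the pair with a measured value, and it lies well inside the range of this assay.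

Compound 3 `CC(C)NC(=O)N1CCN(C(=S)SCc2cn(Cc3ccc(Cl)cc3)nn2)CC1` has not yet been measured. It differs from compound 2 by isopropyl in place of hydrogen on an amide-type nitrogen. The change puts onto the core of compound 2 the same isopropylcarbamoyl group that compound 1 carries, while the rest of compound 2 is left as it is. Among the compounds with values here, no measured step between compounds that differ in one place is available, so the expectation rests on the two values shown. Since compound 1, with the isopropyl group, gives a number where compound 2 gives only a limit, the step from compound 2 to compound 3 is expected to go toward stronger inhibition, by an at least 5.1-fold lower number from compound 2 to compound 3 (0.70 log units; beyond the scatter). For compound 3 the estimate in this assay is 25000 nM, within 7000 nM to 100000 nM.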

Compound 3, half-maximal inhibitory concentration: 25600 nM
Estimate against measurement, compound 3: 1.0-fold (0.01 log units) below; low and high end bracket the measured number.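

In this assay, going by these compounds alone, isopropyl in place of hydrogen on an amide-type nitrogen gives an at least 5.0-fold lower number from compound 2 to compound 3 (0.69 log units; beyond the scatter), the first reading of this change with the 4-chlorophenyl group held constant, and it shows that the group on this nitrogen matters in this pair. As far as these compounds go, the value of compound 2 is a limit and not a number, so the true size of the step stays unknown: the limit of > 128000 nM in this assay, at which 1 of the 3 values shown sits. The second comparison gives a 1.2-fold higher number from compound 1 to compound 3 (0.09 log units; within the scatter), so with the isopropylcarbamoyl group in place, 4-chlorophenyl in place of 2-fluorophenyl on a saturated chain carbon bound to an aromatic nitrogen does not separate the two compounds in this assay.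

The compounds shown carry only hydrogen or isopropyl on this nitrogen, so it remains open how a methyl group, a longer chain or a cyclohexyl group would read there. Also open, from the compounds shown here alone, are how the exchange of the substituted phenyl groups reads with hydrogen on this nitrogen, and whether a methoxy group on the phenyl would leave the value within the scatter.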